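Swapping the amino side chain of compound 2

This account rests on a few compounds, and the source may have more. Where it says the series, first, only, none or still open, it means among the compounds named here.

Measured in a functional assay on LNCaP cells (Homo sapiens) for antiproliferative activity, read by WST assay, with a stated time of 3 days; a lower number here means a stronger inhibitor, a higher number a weaker inhibitor:
Compound 1 `CCCCCCCOc1c(-c2cc(OC)c(OC)c(OC)c2)oc2ccccc2c1=O`: > 50000 nM, a limit of the assay
Compound 2 `CCN(CC)CCCCCOc1c(-c2cc(OC)c(OC)c(OC)c2)oc2ccccc2c1=O`: 10000 nM

Going by the values given here, compound 2 holds the only true number in this assay, at 10000 nM. Compound 1 gives only a limit, > 50000 nM. Compound 3 `CCCCN(CCCC)CCCOc1c(-c2cc(OC)c(OC)c(OC)c2)oc2ccccc2c1=O` is not yet measured and differs from compound 2 in its side chain: dibutylamino in place of 2-(diethylamino)ethyl on a saturated chain carbon, three bonds along the chain from an oxygen on an aromatic ring. Cut further out, this reads 5-(diethylamino)pentyl to 3-(dibutylamino)propyl. Among the compounds with values here, the one measured step, an at least 5.0-fold lower number from compound 1 to compound 2 (0.69 log units; beyond the scatter), brought in the diethylamino group, and compound 3 still carries an amino group, as dibutylamino. That step does not test this exchange, so no change beyond the scatter is expected in this assay. The expected step is a 1.3-fold lower number from compound 2 to compound 3 (0.10 log units; within the scatter). Compound 3 is estimated at 8000 nM, within an expected range of 2500 nM to 30000 nM.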

Compound 3, half-maximal inhibitory concentration: 9000 nM
Beside the measured number, compound 3's estimate is 1.1-fold (0.05 log units) below it; the measured number falls inside the stated range.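

In this assay, 3-(dibutylamino)propyl reads the same as 5-(diethylamino)pentyl, with a 1.1-fold lower number from compound 2 to compound 3 (0.05 log units; within the scatter). The separation from the amine-free side chain therefore holds for a second amino group, with an at least 5.5-fold lower number from compound 1 to compound 3 (0.74 log units; beyond the scatter). Compound 1 gives only a limit, so that step is a bound and not a size: the limit of > 50000 nM in this assay, at which 1 of the 3 values shown sits.

Chain length and amine changed together here, and neither can be read alone. Open too, on these data alone, is how a ring amine such as piperidine or morpholine, or a carboxylic acid, would read in place of dibutylamino.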